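The source may hold more compounds than are shown below. What is called first, only, known or untested is meant among the compounds shown, and "the series" means these compounds.

Measured so far:
compound 1 `CCCCCCSc1n[nH]c(-n2[se]c3ccccc3c2=O)n1` — 20300 nM
compound 2 `O=c1c2ccccc2[se]n1-c1nc(SCc2ccc([N+](=O)[O-])cc2)n[nH]1` — 9140 nM

Across the two compounds tested in a functional assay on A549 cells (Homo sapiens) for antiproliferative activity, read by CCK-8 assay, with a stated time of 48 h (a lower number here means a stronger inhibitor, a higher number a weaker inhibitor), compound 1 gives the higher number, 20300 nM. Compound 2 gives 9140 nM, a lower number by a margin beyond the usual scatter, so compound 1 stands as the weaker of the pair. The next member, compound 3 `CCCCCSc1n[nH]c(-n2[se]c3ccccc3c2=O)n1`, keeps the shared core and differs from compound 1 only in the chain: hydrogen in place of methyl on a saturated chain carbon, five bonds along the chain from a sulfur. Among the compounds with values here, no step between measured compounds of this kind is available, so the size of such a change cannot be read from the series itself. Loss of a methyl from the saturated chain is expected to move the number in this assay only a little, in no particular direction beyond the scatter. The step from compound 1 to compound 3 is estimated at a 1.0-fold lower number from compound 1 to compound 3 (0.01 log units; within the scatter). Compound 3 is accordingly expected to give about 20000 nM in this assay, within a likely range from 8000 nM to 50000 nM.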

Compound 3, half-maximal inhibitory concentration: 21100 nM
The estimate for compound 3 lay 1.1-fold (0.02 log units) below the measured number, and the stated range covers the measured number.
By their numbers in this assay, from the lowest: compound 2; then compounds 1 and 3 (each within the scatter of the next).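

In this assay, hydrogen in place of methyl on a saturated chain carbon, five bonds along the chain from a sulfur, gives a 1.0-fold higher number from compound 1 to compound 3 (0.02 log units; within the scatter) and so stays within the scatter. Within the data shown here, this is the first single-place step, and it shows that removing this methyl leaves the antiproliferative read-out without a detectable change, a point the earlier compounds offered no step to test. No measurement at hand accounts for the size of this step.

As far as these compounds go, whether the same change stays as silent further in along the chain, as ethyl to methyl, propyl to ethyl or butyl to propyl, remains open. Also open, from the compounds shown here alone, is how a longer chain, or an amine or a carboxylic acid at this place, would read in this assay on the shared core.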